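Ether group change from compound 1 to compound 4

The source may hold more compounds than are shown below. What is called first, only, known or untested is meant among the compounds shown, and "the series" means these compounds.

Measured so far in a functional assay on CHO cells for antagonist activity at sphingosine 1-phosphate receptor 2 (Homo sapiens), read by GTPgammaS binding; on this read-out higher numbers stand for weaker inhibition and lower numbers for stronger inhibition:
- compound 1, `O=C(O)Cn1nc(Cc2nc3cc(Cl)c(OCC(F)F)cc3[nH]2)c2ccccc2c1=O`, gives 15 nM
- compound 2, `O=C(O)Cn1nc(Cc2cn3cc(OCC4CC4)c(Cl)cc3n2)c2ccccc2c1=O`, gives 86 nM
- compound 3, `COC(C(=O)O)c1nn(Cc2cn3cc(OCC4CC4)c(Cl)cc3n2)c2ccccc2c1=O`, gives 58 nM

Compound 1 stands lowest of the three in this assay; compound 3 is nearest, with a higher number beyond the scatter, and compound 2 is furthest, also beyond the scatter. Compound 4, `O=C(O)Cn1nc(Cc2nc3cc(Cl)c(OC(F)(F)F)cc3[nH]2)c2ccccc2c1=O`, is not yet measured. It differs from compound 1 in one place: trifluoromethyl in place of 2,2-difluoroethyl on an oxygen on an aromatic ring. For the measured compounds named here, no two measured compounds differ in a single place, so the series gives no direct guide to the size of this step. The leaving and entering groups are close in what is counted, so the step is expected to stay within the scatter: a 1.3-fold higher number from compound 1 to compound 4 (0.12 log units; within the scatter). For compound 4 the estimate in this assay is 20 nM, with a range from 7 nM to 60 nM.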

Compound 4, half-maximal inhibitory concentration: 342 nM
Estimate against measurement, compound 4: 17-fold (1.23 log units) below; the measured number lies above the stated range.
By their numbers in this assay, from the lowest: compound 1; then compounds 3 and 2 (each within the scatter of the next); then compound 4.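

In this assay, the change on an oxygen on an aromatic ring is far from neutral: a 23-fold higher number from compound 1 to compound 4 (1.36 log units; beyond the scatter), although the leaving and entering groups match in heavy-atom count. For the compounds shown here, the group on this oxygen therefore has a large bearing on the read-out, which the earlier compounds, with no single-place pair among them, could not show. Nothing measured on either group bears on this step.

The compounds shown leave open how a methyl, an unfluorinated ethyl or a longer chain such as propyl would read on this oxygen. Going by these compounds, whether the same change carries over to other cores also remains open.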